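Removing the chloro from compound 2

The source may hold more compounds than are shown below. What is called first, only, known or untested is meant among the compounds shown, and "the series" means these compounds.

Compound 2 `O=C(CCl)Nc1ccc(SCC(=O)Nc2cc(Cl)ccn2)cc1` gives 2800 nM in a functional assay on HeLa cells (Homo sapiens) for antiproliferative activity, read by MTT assay, with a stated time of 48 h (a higher number here means a weaker inhibitor, a lower number a stronger inhibitor), the lowest of the two numbers; compound 1 `O=C(CSc1nnc(NC(=O)C(Cl)Cl)s1)Nc1ccc(Br)cn1` gives 15200 nM, a gap beyond the scatter. Compound 3 `O=C(CCl)Nc1ccc(SCC(=O)Nc2ccccn2)cc1` is not yet measured. It differs from compound 2 only as hydrogen in place of chloro on an aromatic carbon. Among the measured compounds shown here, no measured pair isolates this change, so the size of the step is uncertain; a small step toward a higher number, possibly within the scatter, seems most likely. Compound 3 is therefore expected at 4200 nM, with a range of 1500 nM to 12000 nM, a step estimated as a 1.5-fold higher number from compound 2 to compound 3 (0.18 log units; within the scatter).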

Compound 3, half-maximal inhibitory concentration: 7800 nM
For compound 3 the middle estimate is 1.9-fold (0.27 log units) below the measured one, within the range that was stated.
By their numbers in this assay, from the lowest: compound 2; then compounds 3 and 1 (each within the scatter of the next).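

In this assay, going from 4-chloropyridin-2-yl to pyridin-2-yl gives a 2.8-fold higher number from compound 2 to compound 3 (0.44 log units; beyond the scatter). Among the compounds shown here, this is the first pair to isolate this position, and it shows that the chloro opposite the ring nitrogen counts for a modest but real part of the activity of compound 2. No measurement available here bears on the reason for this step.

Still open, on these data alone, is whether a methoxy group, a fluoro or an amine at this position would match the chloro. A single pair also leaves open whether the step would hold with the chloroacetamide replaced.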